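Allyl for Phenyl on the Triazole Nitrogen

The compounds below may be only part of what the source reports. "The series", "measured", "known", "first", "only" and "open" are said of these compounds alone.

Measured so far:
compound 1 `C=CCn1c(SC/C(=N\O)c2ccccc2)nnc1-c1ccc(OC)c(OC)c1`: 69%
compound 2 `COc1ccc(-c2nnc(SCC(=O)c3ccccc3)n2-c2ccccc2)cc1OC`: 59%

In a functional assay on the whole organism (strain albino) for inhibition, with Rattus norvegicus as the target, read by paw edema, with a stated time of 5 h, at a dose of 0.28 mmol/kg by the oral route (a lower number here means less inhibition, a higher number more inhibition at the dose given (going by the name of the read-out)), compound 2 gives 59%, and compound 1 gives 69%; the gap between the two lies within the usual scatter, so neither can be called the stronger. Compound 3 `C=CCn1c(SCC(=O)c2ccccc2)nnc1-c1ccc(OC)c(OC)c1` differs from compound 2 in one place: allyl in place of phenyl on an aromatic nitrogen. Compound 3 thus carries the allyl of compound 1 together with the (benzoylmethyl)sulfanyl group of compound 2. Since compound 1 and compound 2 sit within the scatter of each other, a step from compound 2 to compound 3 of no more than the scatter is expected, in either direction, a number 4 percentage points higher from compound 2 to compound 3 (within the scatter). Compound 3 is estimated at 63%, between 50% and 76%.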

Compound 3, a percentage reported as inhibition, in the whole organism at one dose (the size of the read-out at that dose, not a potency): 62%
Compound 3: middle estimate off by 1 percentage points, on the high side; measured number inside the range.
By their numbers in this assay, from the lowest: compounds 2, 3 and 1 (each within the scatter of the next).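

In this assay, allyl in place of phenyl on the aromatic nitrogen gives a number 3 percentage points higher from compound 2 to compound 3 (within the scatter), so the two groups cannot be told apart at this position. With allyl held on that nitrogen, the exchange of the group on the saturated chain carbon bound to a sulfur gives a number 7 percentage points lower from compound 1 to compound 3 (within the scatter), which also leaves the two compounds undistinguished. No evidence at hand accounts for these readings. On these data alone, it remains open whether a methyl group or a longer chain ending in an amine on that nitrogen would give a step beyond the scatter.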